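From 3-Hydroxybenzyl to 4-Nitrophenyl on a Shared Core

The compounds below may be only part of what the source reports. "The series", "measured", "known", "first", "only" and "open" are said of these compounds alone.

In an ADME assay on HEK-293T cells (Homo sapiens) for cytotoxicity, read by CCK-8 assay, with a stated time of 48 h (on this read-out higher numbers stand for weaker inhibition and lower numbers for stronger inhibition), compound 1 `O=S(=O)(NCCNC(=S)Nc1cc(C(F)(F)F)cc(C(F)(F)F)c1)c1ccc(-c2ccccc2OCc2cccc(O)c2)s1` gives > 20000 nM, which is a limit and not a number. Its standing among the measurements is the limit of > 20000 nM in this assay, at which 1 of the 3 values shown sits.

Two relatives give real numbers. Compound 2 `O=[N+]([O-])c1ccc(NC(=S)NCCNS(=O)(=O)c2ccc(-c3ccccc3OCc3ccccc3)s2)cc1` gives 8900 nM. Compound 3 `Cc1ccc(-c2ccsc2S(=O)(=O)NCCNC(=O)Nc2cc(Cl)cc(Cl)c2)c(Oc2ccc(O)c(O)c2)c1` gives 6700 nM.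

Compound 4 `O=[N+]([O-])c1ccc(Oc2ccccc2-c2ccc(S(=O)(=O)NCCNC(=S)Nc3cc(C(F)(F)F)cc(C(F)(F)F)c3)s2)cc1` keeps the core of compound 1 but carries 4-nitrophenyl in place of 3-hydroxybenzyl on an oxygen on an aromatic ring. For the measured compounds named here, no measured pair shows this change alone, so any forecast is rough. Compound 2, at 8900 nM, also holds a 4-nitrophenyl group, so a moderate move towards lower numbers in this assay is expected. The estimated change is an at least 2.0-fold lower number from compound 1 to compound 4 (0.30 log units; that floor lies within the scatter). For compound 4 the expected value is 10000 nM, within an estimated range of 4000 nM to 20000 nM.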

Compound 4, half-maximal inhibitory concentration: 6000 nM
The estimate for compound 4 lay 1.7-fold (0.22 log units) above the measured number, and the stated range covers the measured number.
By their numbers in this assay, from the lowest: compounds 4, 3 and 2 (each within the scatter of the next). At a limit, above all of these: compound 1.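

In this assay, 4-nitrophenyl in place of 3-hydroxybenzyl on an oxygen on an aromatic ring gives an at least 3.3-fold lower number from compound 1 to compound 4 (0.52 log units; beyond the scatter). For the compounds shown here, this is the first step in the set that changes one place only, and it shows that the group on this oxygen can move the number beyond the scatter. Going by these compounds, the true size of the step remains unknown, because compound 1 stands at a limit: the limit of > 20000 nM in this assay, at which 1 of the 4 values shown sits.

This single step cannot separate the loss of 3-hydroxybenzyl from the arrival of 4-nitrophenyl. On these data alone, how an amine or a carboxylic acid on the ring at this oxygen would read also stays open.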